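The source may report more compounds than this note shows. Statements on the series, on what has been measured and on what is new or still open speak of the compounds shown alone.

Working notes on the series. The shared core is kept in all members; the group on a saturated chain carbon bound to an aromatic nitrogen varies, and compound 2 additionally carries a fluoro group on the core. In a functional assay on MCF7 cells (Homo sapiens) for antiproliferative activity (on this read-out higher numbers stand for weaker inhibition and lower numbers for stronger inhibition), compound 1 `CCC(CC)Cn1c(Cc2cc(OC)c(OC)c(OC)c2)nc2c(N)ncnc21` gives 158000 nM, compound 3 `COc1cc(Cc2nc3c(N)ncnc3n2CC2CC2)cc(OC)c1OC` gives 75900 nM, and compound 2 `CCCCCn1c(Cc2cc(OC)c(OC)c(OC)c2)nc2c(N)nc(F)nc21` gives 36300 nM. Compound 3 therefore stands second highest of the three numbers in this assay, between compound 1 and compound 2. Among the compounds with values here, the single one-point step measured so far is a 2.1-fold lower number from compound 1 to compound 3 (0.32 log units; beyond the scatter), a modest lowering.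

Compound 4 `CCCCCn1c(Cc2cc(OC)c(OC)c(OC)c2)nc2c(N)ncnc21` is not yet measured in this assay. It differs from compound 3 by butyl in place of cyclopropyl on a saturated chain carbon bound to an aromatic nitrogen; cut one bond further out, the change reads cyclopropylmethyl to pentyl. The step from compound 1 to compound 3 bears on it only loosely, since it swapped a branched chain for the ring, whereas here the ring gives way to a straight chain. Within the data shown here, compound 2, which carries pentyl at this place together with a fluoro group, gives 36300 nM in this assay, and compound 4 lacks only that fluoro group. A small step, if any, is expected from compound 3 to compound 4, a 1.5-fold lower number from compound 3 to compound 4 (0.18 log units; within the scatter), within the scatter. Compound 4 is estimated at 50000 nM in this assay, with a range from 20000 nM to 120000 nM.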

Compound 4, half-maximal inhibitory concentration: 61700 nM
Beside the measured number, compound 4's estimate is 1.2-fold (0.09 log units) below it, within the range that was stated.
By their numbers in this assay, from the lowest: compounds 2, 4 and 3 (each within the scatter of the next, the first and the last beyond it); then compound 1.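

In this assay the step with butyl in place of cyclopropyl is a 1.2-fold lower number from compound 3 to compound 4 (0.09 log units; within the scatter) and so does not separate the ring from the straight chain at this position. The step with butyl in place of pentan-3-yl is a 2.6-fold lower number from compound 1 to compound 4 (0.41 log units; beyond the scatter) and runs the same way as a 2.1-fold lower number from compound 1 to compound 3 (0.32 log units; beyond the scatter) so that, among these three groups, only pentan-3-yl stands apart, with the higher number. Hydrogen in place of fluoro on the core gives a 1.7-fold higher number from compound 2 to compound 4 (0.23 log units; within the scatter) and thus no change beyond the scatter with pentyl at this position.

From the compounds shown here alone, whether a longer chain or an amine at this position would move the number beyond the scatter stays open, as does the outcome of the fluoro group alongside cyclopropylmethyl. No available evidence accounts for these numbers.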